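Notes on a furan for pyridine swap in the series

The source may hold more compounds than are shown below. What is called first, only, known or untested is meant among the compounds shown, and "the series" means these compounds.

Compound 1 `Oc1ccc(-c2cc(-c3cccc(Cl)c3)nc(-c3ccccn3)c2)cc1` is the reference point here. In a functional assay on HCT-15 cells (Homo sapiens) for cytotoxicity, read by CCK-8 assay and cell counting, with a stated time of 2 days (on this read-out higher numbers stand for weaker inhibition and lower numbers for stronger inhibition), compound 1 gives 28200 nM, the highest of the two numbers on record. For the measured compounds named here, compound 2 `Oc1cccc(-c2cc(-c3ccc(Cl)cc3)nc(-c3ccco3)c2)c1` gives 10200 nM in this assay, a lower number and beyond the scatter, but compound 2 differs from compound 1 in more than one place, so no single step between the two can be read. Compound 3 `Oc1cccc(-c2cc(-c3cccc(Cl)c3)nc(-c3ccccn3)c2)c1` has no result in this assay: for compound 3 the entry reads "not determined" (no result reported).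

Compound 4 `Oc1ccc(-c2cc(-c3cccc(Cl)c3)nc(-c3ccco3)c2)cc1` is the next compound for this assay. It differs from compound 1 in one place: furan-2-yl in place of pyridin-2-yl on an aromatic carbon. Going by the values given here, no pair of measured compounds differing only in this way is on record, so the size of this step is open. Among the compounds with values here, the only pointer is that compound 2, which carries the same furan-2-yl group, sits at 10200 nM, though its other differences cannot be separated out. For compound 4 a modest drop in the number, at or slightly beyond the scatter, is expected. The expected step is a 1.7-fold lower number from compound 1 to compound 4 (0.22 log units; within the scatter). Compound 4 is estimated at 17000 nM in this assay, with a range from 6000 nM to 50000 nM.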

Compound 4, half-maximal inhibitory concentration: 8020 nM
For compound 4 the middle estimate is 2.1-fold (0.33 log units) above the measured one, and the stated range covers the measured number.
By their numbers in this assay, from the lowest: compounds 4 and 2 (each within the scatter of the next); then compound 1.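

In this assay the series now has its first step that can be read at a single place, with furan-2-yl in place of pyridin-2-yl on the aromatic carbon next to the ring nitrogen: a 3.5-fold lower number from compound 1 to compound 4 (0.55 log units; beyond the scatter). With the 3-chlorophenyl and 4-hydroxyphenyl groups unchanged, this position accepts a five-membered aromatic ring with 1 hetero atom in place of a six-membered one, and the number falls rather than rises, by a modest step that rests on this one pair alone. Nothing on record bears on why the number moves with this change.

On these data alone, whether a thiophene ring, or a non-aromatic group such as an amine or a carboxylic acid, on the same carbon would shift the number further remains open. As far as these compounds go, it is equally open whether the furan-2-yl step carries over when the two phenyl groups bear other substituents, for example a methoxy or an amino group in place of the hydroxyl.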